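The source may report more compounds than this note shows. Statements on the series, on what has been measured and on what is new or still open speak of the compounds shown alone.

Of the compounds shown here, two have been measured in an in vitro assay on HEK385-7 cells for displacement of a labelled ligand from prostaglandin D2 receptor 2 (Homo sapiens); on this read-out lower numbers stand for stronger inhibition and higher numbers for weaker inhibition. Compound 1, `O=C(O)Cc1sc(C(c2ccccc2)c2ccc(Cl)cc2)nc1-c1ccc(F)cc1`, gives 14 nM in this assay. Compound 2, `O=C(O)Cc1sc(C(c2ccc(F)cc2)c2ccc(F)cc2)nc1-c1cccc(F)c1`, gives 1.4 nM in this assay, the lower of the two numbers; compound 1 is its nearest neighbour and sits at a higher number, a gap beyond the usual scatter.

Compound 3, `Nc1cc(-c2nc(C(c3ccc(F)cc3)c3ccc(F)cc3)sc2CC(=O)O)cc(F)n1`, has not yet been measured. It differs from compound 2 in one place: 2-amino-6-fluoropyridin-4-yl in place of 3-fluorophenyl on an aromatic carbon. Among the compounds with values here, no pair of measured compounds shows a change of this kind on the shared core, so the data give no direct guide to its size or direction.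

In the absence of such a guide, the step from compound 2 to compound 3 is expected to be small, a 2.1-fold higher number from compound 2 to compound 3 (0.33 log units; beyond the scatter), within or only a little beyond the scatter, with a slight lean toward a higher number. Compound 3 is therefore estimated to give 3 nM in this assay, within a range of 1 nM to 12 nM.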

Compound 3, half-maximal inhibitory concentration: 220 nM
Estimate against measurement, compound 3: 73-fold (1.87 log units) below, and the stated range ends below it.
By their numbers in this assay, from the lowest: compound 2; then compound 1; then compound 3.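

The position on the aromatic carbon next to the ring nitrogen proved sensitive to the group it carries: in this assay, 2-amino-6-fluoropyridin-4-yl in place of 3-fluorophenyl gives a 160-fold higher number from compound 2 to compound 3 (2.20 log units; beyond the scatter). Within the data shown here, the earlier compounds offered no pair with a change at this place, so this is the first sign that the group here can move the number by a large step. No measurement at hand accounts for the step, and it cannot be assigned to any one part of the change.

The compounds shown leave the ring nitrogen, the amine and the fluorine of the entering group unseparated. As far as these compounds go, it remains open whether the same ring without its amine, or an amine on the fluorophenyl ring, would fall nearer compound 2 or compound 3.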